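A few compounds are considered here, and "the series" means these few. Any claim that something is new, unique, unknown or untested is made for them only; others in the source may bear on it.

Measured in a functional assay on MCF7 cells (Homo sapiens) for cytotoxicity, read by MTT assay, with a stated time of 72 h, tested at 1 uM; a higher number here means more inhibition of growth at the concentration tested, a lower number less inhibition of growth:

compound 1 `Cc1ccnc(/C(N)=N/NC(=S)N2CCOCC2)c1`: 1.22%
compound 2 `Cc1ccnc(/C(N)=N/NC(=S)N2CCSCC2)c1`: 3.89%
compound 3 `Cc1ccnc(/C(N)=N/NC(=S)N2CCCCC2)c1`: 21.2%

Compound 3 stands highest of the three in this assay; its nearest neighbour is compound 2, and the gap a number 17.3 percentage points higher from compound 2 to compound 3 (beyond the scatter) lies beyond the scatter, as does the gap a number 20 percentage points higher from compound 1 to compound 3 (beyond the scatter) to compound 1. The step from compound 1 to compound 2, a number 2.7 percentage points higher from compound 1 to compound 2 (within the scatter), is within the scatter, so the two six-membered rings carrying a second hetero atom cannot be told apart on these numbers.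

Compound 4 `Cc1ccnc(/C(N)=N/NC(=S)N2CCCC2)c1` carries pyrrolidin-1-yl in place of piperidin-1-yl on a thiocarbonyl carbon. Among the compounds with values here, the steps that bear on this are the two ring swaps at the same place, a number 20 percentage points higher from compound 1 to compound 3 (beyond the scatter) and a number 17.3 percentage points higher from compound 2 to compound 3 (beyond the scatter), both modest; each exchange of one saturated ring for another at the thiocarbonyl carbon moved the number by a modest amount at most. The move from a six-membered to a five-membered ring is expected to cost some of the inhibition, by a small step downward or none beyond the scatter: for compound 4 the expected step is a number 7.2 percentage points lower from compound 3 to compound 4 (within the scatter). Compound 4 is therefore estimated at 14%, in the range 3% to 28%.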

Compound 4, percent growth inhibition at one concentration: 49%
Compound 4: the middle estimate sits 35 percentage points below what was measured, and the stated range ends below it.
By their numbers in this assay, from the lowest: compounds 1 and 2 (each within the scatter of the next); then compound 3; then compound 4.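

In this assay, the saturated ring on the thiocarbonyl carbon matters more than the swaps among six-membered rings suggested: pyrrolidin-1-yl in place of piperidin-1-yl gives a number 27.8 percentage points higher from compound 3 to compound 4 (beyond the scatter) and is not the loss that a smaller ring might have implied. Against the rings carrying a second hetero atom, the same five-membered ring gives a number 45.1 percentage points higher from compound 2 to compound 4 (beyond the scatter) and a number 47.8 percentage points higher from compound 1 to compound 4 (beyond the scatter) as the two largest steps in the series. Ring size at this position therefore carries more of the change in inhibition of growth than any exchange among the six-membered rings shown.

No measurement at hand accounts for this rise. Still open, as far as these compounds go, is whether azetidin-1-yl, dimethylamino or a pyrrolidin-1-yl ring bearing a hydroxyl group would keep, extend or lose the gain.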